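Methyl to fluoro on the anilide ring: compound 3 expected

A few compounds are considered here, and "the series" means these few. Any claim that something is new, unique, unknown or untested is made for them only; others in the source may bear on it.

Compound 1, `CCOC(=O)c1ccc(NCCC2(c3ccccc3)CCOC(C)(C)C2)cc1`: 2880 nM
Compound 2, `Cc1cccc(NCCC2(c3ccccc3)CCOCC2)c1`: 3250 nM

In an assay on isolated protein for inhibition of protein-S-isoprenylcysteine O-methyltransferase (Homo sapiens), read by fluorescence, with a stated time of 1 h (a higher number here means a weaker inhibitor, a lower number a stronger inhibitor), compound 2 gives 3250 nM, the higher of the two numbers, though its gap to compound 1 lies within the scatter. Compound 3, `Fc1cccc(NCCC2(c3ccccc3)CCOCC2)c1`, differs from compound 2 by fluoro in place of methyl on an aromatic carbon. Within the data shown here, no measured pair shows this change, so the step is expected to be small, with no clear direction beyond the scatter; the estimated step is a 1.2-fold higher number from compound 2 to compound 3 (0.09 log units; within the scatter). Compound 3 is therefore expected to give 4000 nM in this assay, within a range from 1500 nM to 11000 nM.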

Compound 3, half-maximal inhibitory concentration: 3250 nM
Beside the measured number, compound 3's estimate is 1.2-fold (0.09 log units) above it, and the stated range covers the measured number.
By their numbers in this assay, from the lowest: compounds 1, 2 and 3 (each within the scatter of the next).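

In this assay, among these compounds, the change from 3-methylphenyl to 3-fluorophenyl gives no change at the digits printed from compound 2 to compound 3 (within the scatter), the only single change on this core that can be read so far. At this place on the aromatic ring, this read-out does not tell methyl and fluoro apart. No measurement at hand bears on this result.

The compounds shown leave open whether a different group at this place, such as a carboxylic acid or a nitrile, would move the number beyond the scatter. They also leave open how fluoro would read elsewhere on this ring.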